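Mirror-Image Test for Compound 3

The source may report more compounds than this note shows. Statements on the series, on what has been measured and on what is new or still open speak of the compounds shown alone.

In a functional assay on HeLa cells (Homo sapiens) for cytotoxicity, read by MTT assay, with a stated time of 48 h (a higher number here means a weaker inhibitor, a lower number a stronger inhibitor), compound 1 `CCOC(=O)[C@@]1(C(=O)Nc2ccccc2)C[C@@H]1c1cc(OC)c(OC)c(OC)c1` gives > 100000 nM, which is a limit and not a number. Going by the values given here, compound 2 `CCOC(=O)[C@@]1(C(=O)NCc2ccc(C)cc2)C[C@H]1c1cc(OC)c(OC)c(OC)c1` gives 19700 nM, and compound 3 `CCOC(=O)[C@]1(C(=O)NCc2ccc(C)cc2)C[C@H]1c1cc(OC)c(OC)c(OC)c1` gives 28500 nM, so compound 3 sits within the scatter of the only other number. Compound 4 `CCOC(=O)[C@@]1(C(=O)NCc2ccc(C)cc2)C[C@@H]1c1cc(OC)c(OC)c(OC)c1` follows from compound 3 through the two compounds have the same atoms and bonds and differ only in configuration as drawn: 2 of 2 stereo elements differ (all stereocentres are inverted: mirror images); a stereocentre at a saturated ring carbon is drawn R in compound 3 and S in compound 4; a stereocentre at a saturated ring carbon is drawn S in compound 3 and R in compound 4: all stereocentres are inverted, making the two mirror images. Among the compounds with values here, one measured step bears on this, a 1.4-fold higher number from compound 2 to compound 3 (0.16 log units; within the scatter), and it is a change of configuration alone (the fact that compounds 2 and 3 differ only in the configuration as drawn). It inverted only one stereocentre, so it guides the double inversion only loosely, and no step beyond the scatter is expected. The expected step is a 1.1-fold higher number from compound 3 to compound 4 (0.02 log units; within the scatter). For compound 4 the estimate is 30000 nM, with an expected range of 12000 nM to 90000 nM.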

Compound 4, half-maximal inhibitory concentration: > 100000 nM
Compound 4: a limit, no number (the forecaster's own chance of this, stated with the estimate: 15%); at least 3.3-fold (0.52 log units) between middle value and limit.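

Compound 4 stands at a limit of this assay, not at a number. Inverting both stereocentres gives an at least 3.5-fold higher number from compound 3 to compound 4 (0.54 log units; beyond the scatter), and inverting a single stereocentre gives an at least 5.0-fold higher number from compound 2 to compound 4 (0.70 log units; beyond the scatter), both beyond the scatter, whereas the one earlier single inversion stayed within it. Configuration alone can therefore shift this read-out, which the earlier compounds did not show: the fact that compounds 3 and 4 differ only in the configuration as drawn

The step from compound 1 to compound 4 cannot be read. Going by these compounds, whether the same stereocentres matter as much with a carboxylic acid in place of 4-methylbenzyl stays open.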